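The source may report more compounds than this note shows. Statements on the series, on what has been measured and on what is new or still open speak of the compounds shown alone.

In an ADME assay on Vero cells (Chlorocebus sabaeus) for cytotoxicity, read by crystal violet staining (a lower number here means that less compound is tolerated, a higher number that more compound is tolerated), compound 1 (`CN(/N=N/c1ccccc1)c1ccccc1`) gives 50000 nM and compound 2 (`CN(C)CCCN(/N=N/c1cccc([N+](=O)[O-])c1)c1ccccc1`) gives 40000 nM, so compound 2 stands within the usual scatter of compound 1. Going by the values given here, compound 3 (`CN(/N=N/c1cccc([N+](=O)[O-])c1)c1ccccc1`) has no measurement yet. Its difference from compound 2 is hydrogen in place of 2-(dimethylamino)ethyl on a saturated chain carbon bound to a nitrogen on an aromatic ring, or, cut one bond further out, 3-(dimethylamino)propyl to methyl. Among the compounds with values here, no measured pair shows this change on its own. Compound 3 shares the methyl with compound 1, which gives 50000 nM, so no step beyond the scatter is expected in this assay. The estimated step of a 1.1-fold higher number from compound 2 to compound 3 (0.05 log units; within the scatter) therefore stays small. For compound 3 the expected value is 45000 nM, within an estimated range of 20000 nM to 100000 nM.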

Compound 3, half-maximal cytotoxic concentration: > 100000 nM
Compound 3: no number, only a limit; the forecaster's own chance of this, stated with the estimate: 15%; middle value at least 2.2-fold (0.34 log units) from the limit.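

In this assay the reading for compound 3 is a limit and not a number: the limit of > 100000 nM in this assay, at which 1 of the 3 values shown sits. Hydrogen in place of 2-(dimethylamino)ethyl on a saturated chain carbon bound to a nitrogen on an aromatic ring gives an at least 2.5-fold higher number from compound 2 to compound 3 (0.39 log units; beyond the scatter), the only step in the series so far shown to lie beyond the scatter, so at this position the chain goes with a lower number when the nitro group is present. Nitro in place of hydrogen on an aromatic carbon gives an at least 2.0-fold higher number from compound 1 to compound 3 (0.30 log units; that floor lies within the scatter), so the nitro group brings no fall in the number, though this floor does not separate the pair beyond the scatter.

From the compounds shown here alone, the true size of both steps stays open. The compounds shown also leave open whether the drop belongs to the terminal amine or to the chain itself: a plain propyl group, or a chain ending in a carboxylic acid, would separate the two.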